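Ethoxy gives way to vinyl on the side chain

The compounds below may be only part of what the source reports. "The series", "measured", "known", "first", "only" and "open" are said of these compounds alone.

Of the compounds shown here, three sharing one core have been tested in an ADME assay on RAW264.7 cells (Mus musculus) for cytotoxicity, read by MTT assay, with a stated time of 24 h, in the presence of a further agent that is not named here; on this read-out lower numbers stand for stronger inhibition and higher numbers for weaker inhibition. Compound 1 (`CCCOc1ccc(C(O)C2OC(=O)c3c(OC)cc(OC)cc32)cc1`) gives > 40000 nM as a limit and not a number. Compound 2 (`CCC(C)Oc1ccc(C(O)C2OC(=O)c3c(OC)cc(OC)cc32)cc1`) gives > 40000 nM as a limit too. Compound 3 (`CCOCCOc1ccc(C(O)C2OC(=O)c3c(OC)cc(OC)cc32)cc1`) gives > 40000 nM as a limit again. Compound 3 therefore stands with the others at the limit of > 40000 nM in this assay, at which 3 of the 3 values shown sit, and has no number of its own.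

The change to compound 4 (`C=CCCOc1ccc(C(O)C2OC(=O)c3c(OC)cc(OC)cc32)cc1`) is vinyl in place of ethoxy on a saturated chain carbon, two bonds along the chain from an oxygen on an aromatic ring and puts vinyl in place of ethoxy on a saturated chain carbon, two bonds along the chain from an oxygen on an aromatic ring.

The measured step closest to it, at that same place, is a step that the two limits leave unreadable from compound 1 to compound 3 and it gives no size to build on. The other two (a step that the two limits leave unreadable from compound 1 to compound 2 and a step that the two limits leave unreadable from compound 2 to compound 3) also change only the chain on that oxygen, and neither has a readable size.

The expectation rests on compound 3 at > 40000 nM as a limit, and no step beyond the scatter is expected in this assay in either direction. The expected move is a step that the limit leaves unreadable from compound 3 to compound 4 in this estimate. The estimate for compound 4 is 50000 nM with an expected range of 30000 nM to 100000 nM and a report as a limit is likely.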

Compound 4, half-maximal inhibitory concentration: > 40000 nM
Compound 4 was reported as a limit; the forecaster's own chance of this, stated with the estimate: 85%; the middle value does not contradict the limit.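

In this assay compound 4 gives > 40000 nM, which is a limit and not a number. Among the compounds shown here, its steps from compound 1, compound 2 and compound 3 cannot be read, so this result adds no new step of readable size: the limit of > 40000 nM in this assay, at which 4 of the 4 values shown sit. The compounds shown leave open whether any of these chains on the oxygen changes the read-out in this assay at all, and by how much.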